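The source may report more compounds than this note shows. Statements on the series, on what has been measured and on what is new or still open speak of the compounds shown alone.

Measured so far:
compound 1 `CCCCN(C)c1cc(C(F)(F)F)ccc1CNC(=O)C(C)c1ccc(NS(C)(=O)=O)c(F)c1` gives 1.2 nM in an assay on CHO cells for antagonist activity at transient receptor potential cation channel subfamily V member 1 (Homo sapiens), read by FLIPR; on this read-out higher numbers stand for weaker inhibition and lower numbers for stronger inhibition
compound 2 `CC(C)CCOc1cc(C(F)(F)F)ccc1CNC(=O)C(C)c1ccc(NS(C)(=O)=O)c(F)c1` gives 0.5 nM in this assay

Within the data shown here, compound 2 holds the lowest of the two numbers in this assay; its nearest neighbour is compound 1, and the only step in the set, a 2.4-fold lower number from compound 1 to compound 2 (0.38 log units; beyond the scatter), lies beyond the scatter, so compound 2 sits at the stronger end of what has been measured.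

Compound 3 `CCCCCCSc1cc(C(F)(F)F)ccc1CNC(=O)C(C)c1ccc(NS(C)(=O)=O)c(F)c1` is the next member. Its difference from compound 2 is hexylsulfanyl in place of isopentyloxy on an aromatic carbon. Among the measured compounds shown here, no measured step swaps one chain on this aromatic carbon for another of the same kind; the single step, a 2.4-fold lower number from compound 1 to compound 2 (0.38 log units; beyond the scatter), replaces a nitrogen-linked chain with an oxygen-linked one and is modest in size. That step therefore bears only loosely on the present change, and it gives no reason to expect more than a small shift in this assay in either direction. Compound 3 is accordingly expected to stay close to compound 2, at most a small move toward a higher number, a 1.6-fold higher number from compound 2 to compound 3 (0.20 log units; within the scatter). The estimate for compound 3 in this assay is 0.8 nM, with a range from 0.3 nM to 2.5 nM.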

Compound 3, inhibition constant: 1.8 nM
The estimate for compound 3 lay 2.3-fold (0.35 log units) below the measured number, within the range that was stated.
By their numbers in this assay, from the lowest: compound 2; then compounds 1 and 3 (each within the scatter of the next).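

At the aromatic carbon meta to a trifluoromethyl group, replacing isopentyloxy with hexylsulfanyl gives a 3.6-fold higher number from compound 2 to compound 3 (0.56 log units; beyond the scatter) in this assay, so this position responds to an exchange between two ring-free chains with no net charge and one hydrogen-bond acceptor each. Set against the butyl(methyl)amino chain, the same hexylsulfanyl group gives a 1.5-fold higher number from compound 1 to compound 3 (0.18 log units; within the scatter), which leaves compound 1 and compound 3 without an order between them. Of the three chains, only the isopentyloxy chain of compound 2 stands apart, with its steps to both others beyond the scatter, and no measurement at hand accounts for this difference.

Between compound 2 and compound 3, the linking atom, the chain length and the branching all change together, so the effect of sulfur in place of oxygen cannot be separated from that of the chain; a hexyloxy or an isopentylsulfanyl chain at this carbon would divide them. Also open, from the compounds shown here alone, is how a shorter chain, a piperidine or a chain ending in a carboxylic acid would read at this carbon on the same core.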